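Furan hydrazones: hydroxy capped as methoxy on the benzoyl arm

The source may hold more compounds than are shown below. What is called first, only, known or untested is meant among the compounds shown, and "the series" means these compounds.

Measured so far:
compound 1, `Cc1cccc(/C=N/NC(=O)c2ccc(-c3ccccc3[N+](=O)[O-])o2)c1`, 10.3%
compound 2, `O=C(N/N=C/c1ccc(-c2ccc(F)cc2F)o1)c1ccccc1O`, 61.8%

Both numbers come from a functional assay on KB cells (Homo sapiens) for inhibition, read by sulforhodamine B assay, with a stated time of 48 h, tested at 10 uM; on this read-out lower numbers stand for less inhibition of growth and higher numbers for more inhibition of growth at the one concentration tested. Compound 2 stands at the top of the two values, and its gap to compound 1 lies beyond the scatter; compound 1 sits far down. Compound 3 `COc1ccccc1C(=O)N/N=C/c1ccc(-c2ccc(F)cc2F)o1` has not been measured. It differs from compound 2 by methyl in place of hydrogen on an oxygen on an aromatic ring, that is, the hydroxy on the benzoyl ring becomes methoxy. Among the measured compounds shown here, no two measured compounds differ in just one place, so the size of such a step is not known from this series. The working expectation is that capping the hydroxy lowers growth inhibition in this assay by a step beyond the scatter, while keeping compound 3 clearly above compound 1. For compound 3 the expected value is 38%, within 12% to 64%, which means an expected step of a number 23.8 percentage points lower from compound 2 to compound 3 (beyond the scatter).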

Compound 3, percent growth inhibition at one concentration: 10.1%
Estimate against measurement, compound 3: 27.9 percentage points above; measured number below the stated range.
By their numbers in this assay, from the lowest: compounds 3 and 1 (each within the scatter of the next); then compound 2.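

In this assay, the series now has its first step in one place, and it is large: methyl in place of hydrogen on an oxygen on an aromatic ring gives a number 51.7 percentage points lower from compound 2 to compound 3 (beyond the scatter), with the rest of the structure unchanged. At this position, then, most of the growth inhibition seen at the one concentration tested depends on having hydroxy rather than methoxy on the 2-hydroxyphenyl arm. No measurement bears on why capping the hydroxy has this result.

Going by these compounds, whether an amine or a carboxylic acid in place of the hydroxy would retain the value of compound 2 remains open, as does the outcome with a longer chain such as ethoxy. Also open, on these data alone, is whether the same change would cost as much with a different group on the far side of the shared core.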